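Swapping ethenyl for ethyl on compound 3

The source may hold more compounds than are shown below. What is called first, only, known or untested is meant among the compounds shown, and "the series" means these compounds.

In a functional assay on Jurkat cells (Homo sapiens) for cytotoxicity, read by MTT assay, with a stated time of 72 h (on this read-out higher numbers stand for weaker inhibition and lower numbers for stronger inhibition), compound 1 `COc1ccc(NC(=O)Nc2ccc(C(=O)NO)cc2)cc1` gives 8030 nM, compound 2 `COc1ccc(NC(=O)Nc2ccc(/C=C/C(=O)NO)cc2)cc1` gives 110 nM and compound 3 `O=C(/C=C/c1ccc(NC(=O)Nc2ccc([N+](=O)[O-])cc2)cc1)NO` gives 90 nM. Compound 3 thus sits level with compound 2 and far from compound 1. Compound 4 `O=C(CCc1ccc(NC(=O)Nc2ccc([N+](=O)[O-])cc2)cc1)NO` differs from compound 3 in a single group: 2-(hydroxycarbamoyl)ethyl in place of 2-(hydroxycarbamoyl)ethenyl on an aromatic carbon. Among the compounds with values here, the closest precedent is a 73-fold lower number from compound 1 to compound 2 (1.86 log units; beyond the scatter), a large step that brought in the ethenyl chain. The other step, a 1.2-fold lower number from compound 2 to compound 3 (0.09 log units; within the scatter), stays within the scatter and concerns the far end of the molecule. Within the data shown here, no measured step replaces ethenyl by ethyl directly, so a moderate rise, smaller than the first step, is expected. The expected change in this assay is a 3.9-fold higher number from compound 3 to compound 4 (0.59 log units; beyond the scatter). For compound 4 the estimated value is 350 nM, within a range of 110 nM to 1300 nM.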

Compound 4, half-maximal inhibitory concentration: 810 nM
Compound 4: the middle estimate sits 2.3-fold (0.36 log units) below what was measured; low and high end bracket the measured number.
By their numbers in this assay, from the lowest: compounds 3 and 2 (each within the scatter of the next); then compound 4; then compound 1.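

At this position, on an aromatic carbon para to a large group, the chain keeps its heavy atoms and loses one double bond outside aromatic rings, and in this assay this change alone gives a 9.0-fold higher number from compound 3 to compound 4 (0.95 log units; beyond the scatter). The ethenyl link therefore matters by itself, which the earlier step, where chain and double bond entered together, could not show. Nothing available explains the rise. Still open, as far as these compounds go, is how a longer chain such as 3-(hydroxycarbamoyl)propyl would compare, and whether a carboxylic acid could replace the hydroxycarbamoyl end.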